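Swapping a Pyrrolidine for an Acetamidophenyl Group

The compounds below may be only part of what the source reports. "The series", "measured", "known", "first", "only" and "open" are said of these compounds alone.

Compound 1, `CN1CCN(c2ccc(Nc3ncc4nc(Nc5ccc(F)cc5)n([C@H]5CCCN(C(=O)CO)C5)c4n3)cc2)CC1`, gives 1.8 nM in a functional assay on HCC827 cells (Homo sapiens) for antiproliferative activity, read by MTT assay, with a stated time of 72 h; on this read-out lower numbers stand for stronger inhibition and higher numbers for weaker inhibition.
Compound 2, `CN1CCN(c2ccc(Nc3ncc4nc(Nc5ccccc5)n([C@H]5CCNC5)c4n3)cc2)CC1`, gives 530 nM in this assay.
Compound 3, `CN1CCN(c2ccc(Nc3ncc4nc(Nc5ccc(F)cc5)n([C@H]5CCNC5)c4n3)cc2)CC1`, gives 1220 nM in this assay.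

Compound 3 has the highest number of the three, so it is the weakest of these compounds in this assay. Its nearest neighbour is compound 2, which differs only at the ring bearing the fluorine: a 2.3-fold higher number from compound 2 to compound 3 (0.36 log units; beyond the scatter). Far more striking is the other step: a 680-fold higher number from compound 1 to compound 3 (2.83 log units; beyond the scatter). The group on the aromatic nitrogen of the shared core therefore matters a great deal.

Compound 4, `CC(=O)Nc1cccc(-n2c(Nc3ccc(F)cc3)nc3cnc(Nc4ccc(N5CCN(C)CC5)cc4)nc32)c1`, changes exactly that group: 3-acetamidophenyl in place of pyrrolidin-3-yl on an aromatic nitrogen. Going by the values given here, only one measured step bears on this position, and it shows that the unsubstituted pyrrolidine is a poor choice, with a large loss when it replaces the acylated piperidine of compound 1. Compound 4 carries instead an aromatic ring with an amide, which again brings a hydrogen-bond donor and acceptor. A sizeable drop in the number is expected, though the new group differs from both measured ones, so the estimate is uncertain.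

Compound 4 is expected to give about 30 nM, within a range from 5 nM to 200 nM. The expected change is a 41-fold lower number from compound 3 to compound 4 (1.61 log units; beyond the scatter).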

Compound 4, half-maximal inhibitory concentration: 10 nM
The estimate for compound 4 lay 3.0-fold (0.48 log units) above the measured number; the range from low to high includes it.
By their numbers in this assay, from the lowest: compound 1; then compound 4; then compound 2; then compound 3.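

In this assay, this position accepts a six-membered aromatic ring of carbon only, not just a saturated ring, as the large gain from 3-acetamidophenyl in place of pyrrolidin-3-yl shows (a 120-fold lower number from compound 3 to compound 4 (2.09 log units; beyond the scatter)). The two groups have the same counts of hydrogen-bond donors and acceptors and neither carries a net charge, so these counts cannot account for the step; what does differ is the aromatic ring, the carbonyl and the larger number of heavy atoms. The aromatic group nevertheless does not fully match the 1-((hydroxymethyl)carbonyl)piperidin-3-yl group, as a further modest step remains (a 5.6-fold higher number from compound 1 to compound 4 (0.74 log units; beyond the scatter)).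

Because the ring and the acetamido group enter together in compound 4, the compounds shown cannot tell which of them matters more; a plain phenyl group, or a pyrrolidine carrying an acetyl group on its ring nitrogen, would pull the two apart. Nothing measured here on these groups explains the size of either step.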